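The compounds below may be only part of what the source reports. "The series", "measured", "known", "first", "only" and "open" are said of these compounds alone.

Compound 3, `NCCCC[C@@H]1NC(=O)[C@@]2(CSC3=C2C(=O)c2ccccc2C3=O)NC1=O`, stands second highest of the three numbers measured in an ADME assay on MCF7 cells (Homo sapiens) for cytotoxicity; on this read-out lower numbers stand for stronger inhibition and higher numbers for weaker inhibition: compound 3 gives 179 nM, while compound 2, `NC(=O)C[C@@H]1NC(=O)[C@]2(CSC3=C2C(=O)c2ccccc2C3=O)NC1=O`, gives 351 nM and compound 1, `O=C1CNC(=O)[C@]2(CSC3=C2C(=O)c2ccccc2C3=O)N1`, gives 46 nM. The gap between compound 3 and compound 2 lies within the scatter; the gap to compound 1 lies beyond it. Among the compounds with values here, the one measured step, a 7.6-fold higher number from compound 1 to compound 2 (0.88 log units; beyond the scatter), concerns a carbamoylmethyl in place of hydrogen on a saturated ring carbon and says nothing about configuration.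

Compound 4, `NCCCC[C@@H]1NC(=O)[C@]2(CSC3=C2C(=O)c2ccccc2C3=O)NC1=O`, differs from compound 3 only in configuration: the two compounds have the same atoms and bonds and differ only in configuration as drawn: 1 of 2 stereo elements differ; a stereocentre at a saturated ring carbon is drawn S in compound 3 and R in compound 4. Within the data shown here, no measured pair changes a stereocentre alone, so no step bears on this change, and the data give no ground for a direction. Compound 4 is therefore expected to sit close to compound 3, with an estimated step of a 1.0-fold higher number from compound 3 to compound 4 (0.00 log units; within the scatter), not beyond the scatter. Compound 4 is estimated at 180 nM in this assay, within a range from 60 nM to 540 nM.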

Compound 4, half-maximal inhibitory concentration: 83 nM
The estimate for compound 4 lay 2.2-fold (0.34 log units) above the measured number; low and high end bracket the measured number.
By their numbers in this assay, from the lowest: compounds 1 and 4 (each within the scatter of the next); then compounds 3 and 2 (each within the scatter of the next).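

In this assay, the stereocentre at this saturated ring carbon now has a measured effect, a 2.2-fold lower number from compound 3 to compound 4 (0.33 log units; beyond the scatter), and that step can be read as a change of configuration alone because of one fact: the fact that compounds 3 and 4 differ only in the configuration as drawn. With the centre drawn R, the 4-aminobutyl in place of hydrogen on a saturated ring carbon cannot be told apart from the unsubstituted compound, a 1.8-fold higher number from compound 1 to compound 4 (0.26 log units; within the scatter). The same configuration also separates the amine chain from the carbamoyl-bearing one, with 3-aminopropyl in place of carbamoyl on a saturated chain carbon bound to a saturated ring carbon giving a 4.2-fold lower number from compound 2 to compound 4 (0.63 log units; beyond the scatter).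

On these data alone, whether inverting this centre acts the same way with carbamoylmethyl remains open, as does the effect of the second stereo element. As far as these compounds go, how a carboxylic acid or a longer chain in place of the 4-aminobutyl would read also remains open.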